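A few compounds are considered here, and "the series" means these few. Any claim that something is new, unique, unknown or untested is made for them only; others in the source may bear on it.

Compound 1 `CC(C)(C)c1cc(OC(=O)c2ccco2)ccc1O` carries an ester on the shared core. In an assay on isolated protein for antagonist activity at Bile acid receptor (Homo sapiens), read by HTRF, with a stated time of 30 min (a lower number here means a stronger inhibitor, a higher number a weaker inhibitor), compound 1 reaches only the limit > 100000 nM, which is a limit of the assay and not a number. Compound 2 `CC(C)(C)c1cc(NC(=O)c2c(Cl)cc(N)cc2Cl)ccc1O` has an amide in place of that ester; in this assay compound 2 gives 5200 nM. Among the measured compounds shown here, compound 2 thus holds the only number measured so far. The value of compound 1 sits at the limit of > 100000 nM in this assay, at which 1 of the 2 values shown sits. Compound 3 `CC(C)(C)c1cc(NC(=O)c2c(Cl)cc(NC3CCCC3)cc2Cl)ccc1O` is not yet measured; it differs from compound 2 by cyclopentyl in place of hydrogen on a nitrogen on an aromatic ring, the amino group becoming a cyclopentylamino group. For the measured compounds named here, no step between two measured compounds is available, so the size of the change has no precedent here. The expected step of a 3.5-fold lower number from compound 2 to compound 3 (0.54 log units; beyond the scatter) is a moderate gain in potency, beyond the scatter but not large. For compound 3 the estimate in this assay is 1500 nM, within 300 nM to 8000 nM.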

Compound 3, half-maximal inhibitory concentration: 5000 nM
Compound 3: the middle estimate sits 3.3-fold (0.52 log units) below what was measured; the range from low to high includes it.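

The amino group of compound 2 now has its first readable step in the series: in this assay, the change to a cyclopentylamino group gives a 1.0-fold lower number from compound 2 to compound 3 (0.02 log units; within the scatter) as the result of cyclopentyl in place of hydrogen on a nitrogen on an aromatic ring. This position therefore accepts cyclopentyl, a group of 5 heavy atoms and one five-membered non-aromatic ring, with no shift beyond the scatter, so the gain in potency expected at this nitrogen does not appear. Nothing measured here accounts for this flat step.

Going by these compounds, whether methyl, a longer chain such as hexyl, or a chain ending in a carboxylic acid on the same nitrogen would also leave the number in place remains open. A single step at this position establishes no trend.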